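Trifluoromethyl on the carbamate phenyl of compound 2

The source may hold more compounds than are shown below. What is called first, only, known or untested is meant among the compounds shown, and "the series" means these compounds.

Compound 1 `C[C@@H](OC(=O)Nc1c(-c2ccc(CC(=O)O)cc2)cnn1C)c1ccccc1` carries the carboxymethyl end; in an in vitro functional assay on chem-1 cells for antagonist activity at lysophosphatidic acid receptor 3 (Homo sapiens), read by FLIPR and calcium flux, with stated times of 30 min and 100 s (on this read-out lower numbers stand for stronger inhibition and higher numbers for weaker inhibition), compound 1 gives only a limit, > 30000 nM. Among the measured compounds shown here, compound 2 `C[C@@H](OC(=O)Nc1c(-c2ccc(-c3ccc(C4(C(=O)O)CC4)cc3)cc2)cnn1C)c1ccccc1` is the sole compound with a number in this assay, giving 8340 nM; the step of an at least 3.5-fold lower number from compound 1 to compound 2 (0.55 log units; beyond the scatter) is the only measured change, and it concerns the acid-bearing end, not the carbamate side. Compound 3 `C[C@@H](OC(=O)Nc1c(-c2ccc(-c3ccc(C4(C(=O)O)CC4)cc3)cc2)cnn1C)c1cccc(C(F)(F)F)c1` differs from compound 2 by trifluoromethyl in place of hydrogen on an aromatic carbon. For the measured compounds named here, no measured step touches this position, so no direction is supported. Compound 3 is expected at 5000 nM, between 1200 nM and 20000 nM, the expected step of a 1.7-fold lower number from compound 2 to compound 3 (0.22 log units; within the scatter) lying within the scatter.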

Compound 3, half-maximal inhibitory concentration: 478 nM
The estimate for compound 3 lay 10-fold (1.02 log units) above the measured number, and the stated range ends above it.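

In this assay, the carbamate phenyl proves to be a position where the read-out moves: phenyl to 3-(trifluoromethyl)phenyl gives a 17-fold lower number from compound 2 to compound 3 (1.24 log units; beyond the scatter). Among the compounds shown here, the only earlier measured step concerned the acid-bearing end, so this is the first measured effect on the carbamate side, though it rests on this single pair. Nothing shown bears on why the number falls.

Open, as far as these compounds go, is whether chlorine, methoxy or nitrile at the same carbon gives a similar step, and whether trifluoromethyl elsewhere on this ring does. Also open, from the compounds shown here alone, is whether trifluoromethyl would lower the number with the carboxymethyl end of compound 1.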